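This account rests on a few compounds, and the source may have more. Where it says the series, first, only, none or still open, it means among the compounds named here.

Measured so far:
- compound 1 `O=C1N=C(C2C(=O)c3ccccc3C2=O)CC(/C=C/c2ccccc2)N1`: 17%
- compound 2 `CN(C)c1ccc(C2CC(C3C(=O)c4ccccc4C3=O)=NC(=O)N2)cc1`: 15%

Working notes on the series. In a functional assay on the whole organism for inhibition, with Rattus norvegicus as the target, read by paw edema, with stated times of 30 min and 1 h, at a dose of 10 mg/kg by the oral route (on this read-out higher numbers stand for more inhibition at the one dose given (going by the name of the read-out) and lower numbers for less inhibition), compound 1 gives 17%, the higher of the two numbers recorded, and compound 2 gives 15%. Among the compounds with values here, the one measured step, a number 2 percentage points lower from compound 1 to compound 2 (within the scatter), lies within the scatter, so the two compounds cannot be told apart on this read-out.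

Compound 3 `O=C1N=C(C2C(=O)c3ccccc3C2=O)CC(c2ccco2)N1` is not yet measured. Relative to compound 1 the change is furan-2-yl in place of 2-phenylethenyl on a saturated ring carbon. Within the data shown here, the only step that bears on it is the one from compound 1 to compound 2, which replaced the same 2-phenylethenyl group on the same saturated ring carbon by a different aromatic group and produced a number 2 percentage points lower from compound 1 to compound 2 (within the scatter), a change within the scatter. On that basis the replacement by furan-2-yl is not expected to move this assay beyond the scatter either, in either direction. The expected step is a number 1 percentage points lower from compound 1 to compound 3 (within the scatter). Compound 3 is therefore estimated at 16%, with a range from 8% to 26% in this assay.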

Compound 3, a percentage reported as inhibition, in the whole organism at one dose (the size of the read-out at that dose, not a potency): 18%
The estimate for compound 3 lay 2 percentage points below the measured number; the range from low to high includes it.
By their numbers in this assay, from the lowest: compounds 2, 1 and 3 (each within the scatter of the next).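

In this assay the change at the saturated ring carbon next to the ring nitrogen reads as a number 1 percentage points higher from compound 1 to compound 3 (within the scatter) and the exchange of 4-(dimethylamino)phenyl for furan-2-yl reads as a number 3 percentage points higher from compound 2 to compound 3 (within the scatter) at the same place. This position has now carried three different groups without any step leaving the scatter, and the change from 2-phenylethenyl to furan-2-yl shows that going from 8 heavy atoms to 5, losing the double bond outside aromatic rings and bringing in a hydrogen-bond acceptor together leave the read-out within that scatter. No measurement at hand gives a reason for this result.

An aliphatic amine, a carboxylic acid or a longer alkyl chain on this carbon lies outside the compounds shown, so it remains open whether any group at this position can move the read-out beyond the scatter. Also open, going by these compounds, is how the read-out responds to a change elsewhere on the shared core, such as at the amide hydrogen or on the carbonyl-bearing part, since all three compounds differ only at this one carbon.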